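Naphthyl xylosides with sulfur substituents: antiproliferative working notes

The source may report more compounds than this note shows. Statements on the series, on what has been measured and on what is new or still open speak of the compounds shown alone.

Measured so far:
compound 1 `O[C@@H]1[C@@H](O)[C@H](Oc2cccc3c(S)cccc23)OC[C@H]1O` — 60 uM
compound 2 `O[C@@H]1[C@@H](O)[C@H](Oc2cccc3cccc(S)c23)OC[C@H]1O` — 60 uM
compound 3 `Oc1cccc2c(S[C@@H]3OC[C@@H](O)[C@H](O)[C@H]3O)cccc12` — 135 uM

In an ADME assay on HFL1 cells (Homo sapiens) for antiproliferative activity, read by crystal violet staining, with a stated time of 96 h (a lower number here means that less compound is needed, a higher number that more compound is needed for the effect), compound 1 gives 60 uM, level at the digits shown with compound 2, which gives 60 uM; together these two are the lowest of the three numbers. Compound 3 gives 135 uM in this assay, the furthest from compound 1 and a higher number beyond the scatter.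

Going by the values given here, no pair of measured compounds differs in one place only, so the size of a single-point change is not anchored by any measured step in this assay. Compound 4 `CCCSc1cccc2c(O[C@@H]3OC[C@@H](O)[C@H](O)[C@H]3O)cccc12` is not yet measured. It differs from compound 1 by propyl in place of hydrogen on a sulfur; cut one bond further out, the change reads sulfanyl to propylsulfanyl.

With nothing comparable measured, the expected step in this assay is small, if any beyond the scatter, and more likely toward a somewhat higher number than a lower one. The expected step is a 1.5-fold higher number from compound 1 to compound 4 (0.18 log units; within the scatter). Compound 4 is estimated at 90 uM, with a range from 30 uM to 250 uM.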

Compound 4, concentration for half-maximal effect: 20 uM
The estimate for compound 4 lay 4.5-fold (0.65 log units) above the measured number; measured number below the stated range.
By their numbers in this assay, from the lowest: compound 4; then compounds 1 and 2 (each within the scatter of the next); then compound 3.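

In this assay, propyl in place of hydrogen on a sulfur gives a 3.0-fold lower number from compound 1 to compound 4 (0.48 log units; beyond the scatter), a modest step beyond the scatter and the first single-place step the series provides. The earlier compounds shown here gave no reading of any change at this sulfur; this step shows that the sulfanyl hydrogen of compound 1 is not required for the effect in this assay, and that a propyl group on this sulfur is compatible with a lower number. No measured evidence in hand accounts for the direction or size of this step.

On these data alone, with only the propyl group measured here, it remains open whether a shorter ethyl or methyl chain, a longer butyl or hexyl chain, or a chain ending in an amine or a carboxylic acid would lower the number further, leave it level or raise it. As far as these compounds go, it is also open whether the same propyl change on the sulfur of compound 2 would give a step of similar size and direction, so the result cannot yet be extended beyond the core of compound 1.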